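This account rests on a few compounds, and the source may have more. Where it says the series, first, only, none or still open, it means among the compounds named here.

Of the compounds shown here, three sharing one core have been measured in a functional assay on Shh Light II cells (Mus musculus) for inhibition, read by a luciferase reporter; on this read-out lower numbers stand for stronger inhibition and higher numbers for weaker inhibition. Compound 1 (`CC(=O)N1CCC(NC(=O)N2CCC(c3nc(-c4ccc5ccccc5n4)no3)CC2)CC1`) gives 500 nM, compound 2 (`COc1ccccc1NC(=O)N1CCC(c2nc(-c3ccc4ccccc4n3)no2)CC1`) gives 410 nM, and compound 3 (`COc1ccccc1OC(=O)N1CCC(c2nc(-c3ccc4ccccc4n3)no2)CC1`) gives 250 nM. Compound 3 thus stands within the scatter of both others, and the three cannot be ranked. The next compound, compound 4 (`O=C(NC1CCOCC1)N1CCC(c2nc(-c3ccc4ccccc4n3)no2)CC1`), carries (oxan-4-yl)amino in place of 2-methoxyphenoxy on a carbonyl carbon. Among the measured compounds shown here, two measured steps concern the same place and the same leaving group. One is a 2.0-fold lower number from compound 1 to compound 3 (0.30 log units; within the scatter), where (1-acetylpiperidin-4-yl)amino gives way to 2-methoxyphenoxy. The other is a 1.6-fold lower number from compound 2 to compound 3 (0.21 log units; within the scatter), where (2-methoxyphenyl)amino gives way to it. The exchange between the two amino groups, a 1.2-fold lower number from compound 1 to compound 2 (0.09 log units; within the scatter), is equally small. Read in reverse, these steps suggest a somewhat higher number in this assay on leaving 2-methoxyphenoxy, though nothing expected beyond the scatter. The estimate amounts to an expected 1.8-fold higher number from compound 3 to compound 4 (0.26 log units; within the scatter). Compound 4 is expected at 450 nM, with an estimated range of 180 nM to 1100 nM.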

Compound 4, half-maximal inhibitory concentration: 480 nM
Estimate against measurement, compound 4: 1.1-fold (0.03 log units) below, within the range that was stated.
By their numbers in this assay, from the lowest: compounds 3, 2, 4 and 1 (each within the scatter of the next).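

On the carbonyl carbon in this assay, (oxan-4-yl)amino joins the earlier groups without any step leaving the scatter (a 1.9-fold higher number from compound 3 to compound 4 (0.28 log units; within the scatter); a 1.2-fold higher number from compound 2 to compound 4 (0.07 log units; within the scatter); a 1.0-fold lower number from compound 1 to compound 4 (0.02 log units; within the scatter)). With four different groups now in place, the flat picture extends to a six-membered non-aromatic ring with 1 hetero atom, so an aromatic ring of carbon only is not needed here for a number in this range, and neither is the acetyl-bearing piperidine of compound 1. Nothing available explains why this place responds so little.

The compounds shown leave open whether any group here can move the number beyond the scatter, such as a small dimethylamino group, a simple methyl or a chain ending in a carboxylic acid. They also leave open whether changes elsewhere on the shared core would matter more.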